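The source may report more compounds than this note shows. Statements on the series, on what has been measured and on what is new or still open speak of the compounds shown alone.

Measured compounds:
- compound 1 `COc1nc(N)nc2c1c(-c1cc3ccccc3o1)cn2[C@@H]1O[C@H](CO)[C@@H](O)[C@H]1O`: 22700 nM
- compound 2 `COc1ncnc2c1c(-c1cccs1)cn2[C@@H]1O[C@H](CO)[C@@H](O)[C@H]1O`: 43200 nM
- compound 3 `Cc1ncnc2c1c(-c1cc3ccccc3o1)cn2[C@@H]1O[C@H](CO)[C@@H](O)[C@H]1O`: 84400 nM

In an ADME assay on MRC5 cells (Homo sapiens), read by MTT assay, with a stated time of 72 h (on this read-out higher numbers stand for weaker inhibition and lower numbers for stronger inhibition), compound 3 gives 84400 nM, the highest of the three numbers. Compound 2 gives 43200 nM, which lies within the scatter of compound 3, so no order between the two can be read. Compound 1 gives 22700 nM, a number beyond the scatter below compound 3; compound 1 carries a methoxy and an amino group and so differs from compound 3 in more than one place.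

Compound 4 `COc1ncnc2c1c(-c1cc3ccccc3o1)cn2[C@@H]1O[C@H](CO)[C@@H](O)[C@H]1O` is not yet measured. It differs from compound 3 in one place: methoxy in place of methyl on an aromatic carbon. Among the measured compounds shown here, no pair of measured compounds shows this change alone. Compounds 1 and 2 both carry the methoxy and both give lower numbers than compound 3, but each also differs from compound 3 elsewhere, so they give only a loose hint of direction.

The step from compound 3 to compound 4 is expected to be a 1.7-fold lower number from compound 3 to compound 4 (0.23 log units; within the scatter), toward a somewhat lower number, but it may well stay within the scatter. Compound 4 is estimated at 50000 nM in this assay, with a range from 20000 nM to 120000 nM.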

Compound 4, half-maximal inhibitory concentration: 65600 nM
Beside the measured number, compound 4's estimate is 1.3-fold (0.12 log units) below it, and the stated range covers the measured number.
By their numbers in this assay, from the lowest: compounds 1, 2, 4 and 3 (each within the scatter of the next, the first and the last beyond it).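

Methoxy in place of methyl on an aromatic carbon, next to the ring nitrogen, gives a 1.3-fold lower number from compound 3 to compound 4 (0.11 log units; within the scatter) in this assay and so shows no readable change at this position. The aryl exchange, 1-benzofuran-2-yl in place of thiophen-2-yl, gives a 1.5-fold higher number from compound 2 to compound 4 (0.18 log units; within the scatter) and also stays without a readable change, so the lower number of compound 2 does not point to an effect of the methoxy. Hydrogen in place of amino gives a 2.9-fold higher number from compound 1 to compound 4 (0.46 log units; beyond the scatter) as the only step here beyond the scatter, a modest one, which makes the amino group rather than the methoxy the one change with a readable step.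

No measurement available here accounts for any of these steps. As far as these compounds go, it remains open whether an ethoxy group, a dimethylamino group or a carboxylic acid at this position would move the number beyond the scatter, and whether amino has the same step when methyl stands in place of methoxy.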